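The source may report more compounds than this note shows. Statements on the series, on what has been measured and on what is new or still open speak of the compounds shown alone.

Of the compounds shown here, three sharing one core have been tested in a functional assay on A549 cells (Homo sapiens) for inhibition, read by MTT assay, with a stated time of 72 h; a lower number here means a stronger inhibitor, a higher number a weaker inhibitor. Compound 1 `CC(C)(C)n1cc2c(n1)C(=O)CC1(CCN(C(=O)c3cc(-c4ccc(Cl)cc4)nc4ccccc34)CC1)O2` gives 2330 nM. Compound 2 `COc1ccc(-c2cc(C(=O)N3CCC4(CC3)CC(=O)c3nn(C(C)(C)C)cc3O4)c3ccccc3n2)cc1` gives 3740 nM in this assay. Compound 3 `CC(C)(C)n1cc2c(n1)C(=O)CC1(CCN(C(=O)c3cc(Cl)nc4ccccc34)CC1)O2` gives 7170 nM in this assay. The cores of compound 1 and compound 3 differ by chloro in place of 4-chlorophenyl on an aromatic carbon, and that change brought a 3.1-fold higher number from compound 1 to compound 3 (0.49 log units; beyond the scatter). Compound 2 and compound 3 sit within the scatter of each other, as a 1.9-fold higher number from compound 2 to compound 3 (0.28 log units; within the scatter) shows.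

Compound 4 `COc1cc(C(=O)N2CCC3(CC2)CC(=O)c2nn(C(C)(C)C)cc2O3)c2ccccc2n1` has not been measured. It differs from compound 3 by methoxy in place of chloro on an aromatic carbon. The same kind of change has been made once already, from compound 1 to compound 2, where it read (methoxy in place of chloro on an aromatic carbon); that step was a 1.6-fold higher number from compound 1 to compound 2 (0.21 log units; within the scatter). The surroundings differ, though: in compound 1 the change sits on a six-membered aromatic ring of carbon only, para to a large group, whereas in compound 3 it sits on a six-membered aromatic ring with 1 nitrogen, part of a fused or bridged system of two rings, next to the ring nitrogen. So the two changes are of the same kind, not the same.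

Because a 1.6-fold higher number from compound 1 to compound 2 (0.21 log units; within the scatter) stayed within the scatter, the step expected here, a 1.4-fold higher number from compound 3 to compound 4 (0.14 log units; within the scatter), is also small. Compound 4 is estimated at 10000 nM in this assay, with a likely span from 4000 nM to 25000 nM.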

Compound 4, half-maximal inhibitory concentration: > 10000 nM
Compound 4: a limit, no number; the forecaster's own chance of this, stated with the estimate: 20%; the middle value sits exactly at the limit.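

In this assay, compound 4 gives > 10000 nM, which is a limit of the assay and not a number. Methoxy in place of chloro can be compared across the two cores only in part: the same change on two cores in this assay, a 1.6-fold higher number (0.21 log units; within the scatter) from compound 1 to compound 2 and an at least 1.3-fold higher number (0.14 log units; that floor lies within the scatter) from compound 3 to compound 4; the limit leaves it open whether they differ Replacing either aryl group with methoxy gave an at least 2.6-fold higher number from compound 2 to compound 4 (0.42 log units; beyond the scatter) and an at least 4.2-fold higher number from compound 1 to compound 4 (0.63 log units; beyond the scatter), both floors beyond the scatter, while an at least 1.3-fold higher number from compound 3 to compound 4 (0.14 log units; that floor lies within the scatter) is a floor within it, so these compounds do not show whether the chloro-to-methoxy step on this core is as small as the one on the core of compound 1.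

The compounds shown leave open how an amine, a hydroxyl or a plain phenyl would read on this aromatic carbon of the ring with one nitrogen. Going by these compounds, the true size of the chloro-to-methoxy step on this core also stays open, with only a limit for compound 4.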